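This account rests on a few compounds, and the source may have more. Where it says the series, first, only, none or still open, it means among the compounds named here.

Compound 1 `CC/C(=C(/c1ccccc1)c1ccc(NC(=O)C(C)C)cc1)c1ccc(OCc2ccccc2)cc1` in a functional assay on MCF7 cells (Homo sapiens) for inhibition, read by trypan blue exclusion, with a stated time of 72 h (a higher number here means a weaker inhibitor of growth, a lower number a stronger inhibitor of growth), gives > 30000 nM, which is a limit of the assay rather than a number.
Compound 2 `CC/C(=C(\c1ccc(NC(=O)C(C)C)cc1)c1ccc(OC)cc1)c1ccc(OCc2ccccc2)cc1` in this assay gives > 30000 nM, again a limit of the assay and not a number.
Compound 3 `CC/C(=C(/c1ccccc1)c1ccc(NC(=O)C(C)C)cc1)c1ccc(Cl)cc1Cl` in this assay gives 17500 nM.

All three share an amide-bearing alkene core, and the fourth member of the set, compound 4 `CC/C(=C(\c1ccc(NC(=O)C(C)C)cc1)c1ccc(OC)cc1)c1ccc(Cl)cc1Cl`, has not yet been measured in this assay.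

Compound 1 and compound 2 differ in one place: methoxy in place of hydrogen on an aromatic carbon. The size of this step, a step that the two limits leave unreadable from compound 1 to compound 2, cannot be read, because of the limit of > 30000 nM in this assay, at which 2 of the 3 values shown sit.

Compound 3 carries a different core from compound 1; the difference between the two cores is not broken down here. Compound 3 is the only one of the three that gives an actual number in this assay.

Compound 4 is reached from compound 3 by the same change: methoxy in place of hydrogen on an aromatic carbon. Going by the values given here, the only earlier example of this change sits between two limits, so no measured size is available to carry over. The expectation for compound 4 therefore rests on compound 3 alone, because compound 3 gives 17500 nM in this assay. The step from compound 3 to compound 4 is expected to be small, a 1.0-fold lower number from compound 3 to compound 4 (0.01 log units; within the scatter), with wide uncertainty. Compound 4 is expected to give about 17000 nM in this assay, between 5000 nM and 40000 nM.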

Compound 4, concentration for 50% growth inhibition: 13200 nM
Compound 4: middle estimate off by 1.3-fold (0.11 log units), on the high side, within the range that was stated.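

In this assay, going by these compounds alone, the one pair where this change can be read shows a 1.3-fold lower number from compound 3 to compound 4 (0.12 log units; within the scatter), so swapping hydrogen for methoxy, which turns a phenyl into a 4-methoxyphenyl, shifts the number by no more than repeated measurements of one compound would. The same change on the core of compound 1 gives no second size to set beside it, and that step cannot be read, because both of its compounds give only a limit of the assay and not a number: the limit of > 30000 nM in this assay, at which 2 of the 4 values shown sit. The series therefore offers a single readable example on a single core, which shows that the change did little there but does not show that it would do equally little on another core, or that its size carries from one core to the other.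

Among the compounds shown, this place on the ring holds only hydrogen or methoxy, so what an amine, a carboxylic acid or a longer ether chain there would do remains open. All four compounds also carry the same amide, which leaves open what a longer chain on its carbonyl would do to growth inhibition on either core.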